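Trimming the acyl chain on a cytotoxic tetracyclic scaffold

A few compounds are considered here, and "the series" means these few. Any claim that something is new, unique, unknown or untested is made for them only; others in the source may bear on it.

Among the compounds with values here, in a functional assay on HeLa cells (Homo sapiens) for cytotoxicity, read by MTT assay (on this read-out higher numbers stand for weaker inhibition and lower numbers for stronger inhibition), compound 2 `CCC(=O)c1ccc2c(c1O)[C@@H]1c3c(ccc4c(=O)c(-c5ccccc5)c(C)oc34)OC[C@@H]1C(C)(C)O2` gives 18200 nM, the only number among the two values shown. Compound 1 `CC(=O)c1ccc2c(c1O)[C@@H]1c3c(ccc4c(=O)c(C)c(C)oc34)OC[C@@H]1C(C)(C)O2` reaches only a limit of the assay, > 100000 nM, so (the limit of > 100000 nM in this assay, at which 1 of the 2 values shown sits). Compound 3 `CC(=O)c1ccc2c(c1O)[C@@H]1c3c(ccc4c(=O)c(-c5ccccc5)c(C)oc34)OC[C@@H]1C(C)(C)O2` differs from compound 2 by hydrogen in place of methyl on a saturated chain carbon bound to a carbonyl carbon. Within the data shown here, no step between measured compounds speaks to this change, so little shift beyond the scatter is expected, and the estimated step of a 1.4-fold higher number from compound 2 to compound 3 (0.14 log units; within the scatter) is put at a slight weakening. Compound 3 is therefore expected to give about 25000 nM, between 9000 nM and 70000 nM.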

Compound 3, half-maximal inhibitory concentration: 4810 nM
Estimate against measurement, compound 3: 5.2-fold (0.72 log units) above; the measured number lies below the stated range.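

Shortening propanoyl to acetyl gives a 3.8-fold lower number from compound 2 to compound 3 (0.58 log units; beyond the scatter) in this assay and so shows that this saturated chain carbon bound to a carbonyl carbon matters, which compound 1 and compound 2 could not show, differing as they do in two places. Phenyl in place of methyl on an aromatic carbon gives an at least 20-fold lower number from compound 1 to compound 3 (1.31 log units; beyond the scatter) as the larger of the two steps. That step rests on a limit and not on a number: the limit of > 100000 nM in this assay, at which 1 of the 3 values shown sits.

The compounds shown leave open whether a longer chain such as butanoyl would weaken the number further. From the compounds shown here alone, it also remains open whether an amine or a carboxylic acid could stand in place of phenyl on that aromatic carbon.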